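Compound 2 to compound 3: fluoro replaced by hydrogen

This account rests on a few compounds, and the source may have more. Where it says the series, first, only, none or still open, it means among the compounds named here.

- compound 1 `COc1cc(C=C(C(=O)/C=C/c2ccc(N(C)C)cc2)C(=O)/C=C/c2ccc(N(C)C)cc2)ccc1O`: 75.4 ug/mL
- compound 2 `CN(C)c1ccc(/C=C/c2cc(/C=C/c3ccc(N(C)C)cc3)n(-c3ccc(F)cc3)n2)cc1`: 74.4 ug/mL

In a physicochemical assay, read by spectrophotometry (a higher number here means a weaker inhibitor, a lower number a stronger inhibitor), compound 2 gives 74.4 ug/mL, within the scatter of compound 1 at 75.4 ug/mL. Compound 3 `CN(C)c1ccc(/C=C/c2cc(/C=C/c3ccc(N(C)C)cc3)n(-c3ccccc3)n2)cc1` differs from compound 2 by hydrogen in place of fluoro on an aromatic carbon, para to a large group. For the measured compounds named here, no measured pair isolates this change, so no step beyond the scatter is expected, in either direction. The expected change is a 1.0-fold higher number from compound 2 to compound 3 (0.00 log units; within the scatter). For compound 3 the estimated value is 75 ug/mL, with an expected range from 40 ug/mL to 140 ug/mL.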

Compound 3, half-maximal inhibitory concentration: 74 ug/mL
Beside the measured number, compound 3's estimate is 1.0-fold (0.01 log units) above it; low and high end bracket the measured number.
By their numbers in this assay, from the lowest: compounds 3, 2 and 1 (each within the scatter of the next).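

In this assay, for the compounds shown here, the change from 4-fluorophenyl to phenyl gives a 1.0-fold lower number from compound 2 to compound 3 (0.00 log units; within the scatter) and is the first measured pair to isolate this change. On this aromatic carbon, para to a large group, fluoro and hydrogen therefore cannot be told apart. No measurement shown bears on why the two read alike.

Open, from the compounds shown here alone, is whether another group on that carbon, such as methoxy, trifluoromethyl or a carboxylic acid, would separate from hydrogen and fluoro in this assay at all. Compound 1 differs from compound 2 in more than one place, so the role of the shared dimethylamino groups also stays unresolved.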